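Swapping the hydrazone aryl group: a dichlorophenyl returns

The source may hold more compounds than are shown below. What is called first, only, known or untested is meant among the compounds shown, and "the series" means these compounds.

Measured compounds:
compound 1 `CN(C)CCn1cnnc1-c1cc(Oc2ccc(NC(=O)N/N=C/c3cccc(Cl)c3Cl)cc2F)ccn1` gives 72 nM;
compound 2 `CN(C)CCn1cnnc1-c1cc(Oc2ccc(NC(=O)N/N=C/c3ccc(O)c(F)c3)cc2F)ccn1` gives 2620 nM;
compound 3 `COc1ccc(/C=N/NC(=O)Nc2ccc(Oc3ccnc(-c4nncn4CCN(C)C)c3)c(F)c2)c(OC)c1OC` gives 1790 nM.

In a functional assay on NCI-H460 cells (Homo sapiens) for cytotoxicity, read by MTT assay, with a stated time of 72 h (a lower number here means a stronger inhibitor, a higher number a weaker inhibitor), compound 2 has the highest number of the three. Its nearest neighbour is compound 3, and the step of a 1.5-fold lower number from compound 2 to compound 3 (0.17 log units; within the scatter) lies within the scatter, so these two cannot be told apart. Its furthest neighbour is compound 1, reached by the step of a 36-fold higher number from compound 1 to compound 2 (1.56 log units; beyond the scatter).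

Compound 4 `CN(C)CCn1cnnc1-c1cc(Oc2ccc(NC(=O)N/N=C/c3c(Cl)cccc3Cl)cc2F)ccn1` differs from compound 2 in one place: 2,6-dichlorophenyl in place of 3-fluoro-4-hydroxyphenyl on a carbon with a double bond to nitrogen. The step that bears most directly on this change is a 36-fold higher number from compound 1 to compound 2 (1.56 log units; beyond the scatter), where the only difference was a dichlorophenyl group against the 3-fluoro-4-hydroxyphenyl group. The related step of a 25-fold higher number from compound 1 to compound 3 (1.40 log units; beyond the scatter) was of a similar size. Reversing that kind of change is therefore expected to give a large step in this assay toward a lower number, though the chlorine atoms now sit in a different arrangement, so the full return is uncertain.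

For compound 4 the expected value is 150 nM, with a range from 40 nM to 800 nM. The expected step is a 17-fold lower number from compound 2 to compound 4 (1.24 log units; beyond the scatter), estimated because of the size of a 36-fold higher number from compound 1 to compound 2 (1.56 log units; beyond the scatter).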

Compound 4, half-maximal inhibitory concentration: 350 nM
Compound 4: the middle estimate sits 2.3-fold (0.37 log units) below what was measured, within the range that was stated.
By their numbers in this assay, from the lowest: compound 1; then compound 4; then compounds 3 and 2 (each within the scatter of the next).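

In this assay, the 2,6-dichlorophenyl group of compound 4 gives a lower number than either group without chlorine, with a 7.5-fold lower number from compound 2 to compound 4 (0.87 log units; beyond the scatter) and a 5.1-fold lower number from compound 3 to compound 4 (0.71 log units; beyond the scatter), so among these compounds the advantage of a dichlorophenyl group is not confined to the 2,3-dichlorophenyl arrangement. The arrangement still counts, however: a 4.9-fold higher number from compound 1 to compound 4 (0.69 log units; beyond the scatter) shows that moving the chlorine atoms gives back part of that advantage. Nothing available explains why the arrangement of the chlorine atoms changes the number.

The compounds shown leave open how far a plain phenyl group or a chlorophenyl group would carry the same advantage. They also leave open whether a dibromophenyl or dimethylphenyl group would match the dichlorophenyl groups, which would test whether chlorine itself is needed.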